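Trifluoromethyl to amino: working notes on the series

The source may hold more compounds than are shown below. What is called first, only, known or untested is meant among the compounds shown, and "the series" means these compounds.

- Compound 1 `Cc1cc(NC(=O)Nc2ccc(C(C)(C)C)cc2)c2ccccc2n1` gives > 25000 nM as a limit
- Compound 2 `Cc1cc(NC(=O)Nc2ccc(C(F)(F)F)cc2)c2ccccc2n1` gives 23000 nM as a number

Going by the values given here, in an ADME assay on Raji cells (Homo sapiens) for cytotoxicity, with a stated time of 72 h (a lower number here means that less compound is needed, a higher number that more compound is needed for the effect), compound 2 at 23000 nM holds the only number so far. Compound 1 stands at > 25000 nM and that is a limit only. Among the compounds with values here, the single measured step of an at least 1.0-fold lower number from compound 1 to compound 2 (0.03 log units; that floor lies within the scatter) stays within the scatter and gives a floor rather than a size. Compound 3 `Cc1cc(NC(=O)Nc2ccc(N)cc2)c2ccccc2n1` differs from compound 2 at that same place (amino in place of trifluoromethyl on an aromatic carbon) with amino in place of trifluoromethyl. Within the data shown here, with the step of an at least 1.0-fold lower number from compound 1 to compound 2 (0.03 log units; that floor lies within the scatter) as the only guide, and a different pair of groups involved there, no step beyond the scatter is expected in this assay and confidence is low. The expected step is a 1.3-fold lower number from compound 2 to compound 3 (0.11 log units; within the scatter) and so stays within the scatter. For compound 3 the estimated value is 18000 nM (expected range 6000 nM to 40000 nM).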

Compound 3, half-maximal effective concentration: > 25000 nM
Compound 3: no number, only a limit (the forecaster's own chance of this, stated with the estimate: 40%); middle value at least 1.3-fold (0.14 log units) away from the limit.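

In this assay compound 3 gives > 25000 nM, which is a limit and not a number. The change from trifluoromethyl to amino gives an at least 1.0-fold higher number from compound 2 to compound 3 (0.03 log units; that floor lies within the scatter), so this second change at the same place also yields only a floor within the scatter, and the step between compound 1 and compound 3 cannot be read. What is new is that the same limit now recurs with two different groups at this place, tert-butyl and amino: the limit of > 25000 nM in this assay, at which 2 of the 3 values shown sit.

From the compounds shown here alone, whether a carboxylic acid, a hydroxyl or a longer chain at this place would give a number clearly apart from that of compound 2 remains open. Going by these compounds, how far compound 1 and compound 3 actually lie from compound 2 also remains open.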